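Metabolic stability notes: azaindole to benzimidazole amide swap

The source may hold more compounds than are shown below. What is called first, only, known or untested is meant among the compounds shown, and "the series" means these compounds.

Measured so far:
- compound 1 `O=C(NCc1ccc(S(=O)(=O)N2CCCCC2)cc1)c1cc2ccncc2[nH]1`, 50%
- compound 2 `O=C(NCc1ccc(S(=O)(=O)c2ccccc2)cc1)c1nc2cnccc2[nH]1`, 73%

In an ADME assay on microsomes from liver (Homo sapiens) for metabolic stability, read by LC-MS, with a stated time of 30 min, tested at 1 uM (on this read-out lower numbers stand for a less stable compound and higher numbers for a more stable compound), compound 1 gives 50%, and in the same assay compound 2 gives 73%. Compound 1 therefore stands lowest of the two numbers recorded; compound 2 lies higher by a gap beyond the scatter. Going by the values given here, the two differ in more than one place, so no single step is drawn between them and only the pair of values is noted.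

The compound now in question is compound 3 `O=C(NCc1ccc(S(=O)(=O)N2CCCCC2)cc1)c1ccc2nc[nH]c2c1`. Relative to compound 1 the change is a group of 9 heavy atoms (7 carbon, 2 nitrogen; one five-membered aromatic ring with 2 hetero atoms, one six-membered aromatic ring of carbon only) in place of a group of 9 heavy atoms (7 carbon, 2 nitrogen; one five-membered aromatic ring with 1 hetero atom, one six-membered aromatic ring with 1 hetero atom), on a carbonyl carbon, the two having the same atoms joined differently, on the carbonyl carbon whose other neighbour is the amide-type nitrogen. Among the compounds with values here, no step between measured compounds covers such a rearrangement, so the direction is open. Given compound 1 at 50%, the expected step of a number 5 percentage points higher from compound 1 to compound 3 (within the scatter) is small, likely within the scatter or only just beyond it. Compound 3 is accordingly estimated at 55%, with a range from 30% to 80%.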

Compound 3, percent of the compound remaining: 53%
Compound 3: middle estimate off by 2 percentage points, on the high side; the range from low to high includes it.
By their numbers in this assay, from the lowest: compounds 1 and 3 (each within the scatter of the next); then compound 2.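

In this assay, putting 1H-benzimidazol-6-yl on the carbonyl carbon in place of the group with a five-membered aromatic ring with 1 hetero atom and a six-membered aromatic ring with 1 hetero atom gives a number 3 percentage points higher from compound 1 to compound 3 (within the scatter). Going by these compounds alone, for this one pair, a rearrangement of the same atoms at this position, with the same counts of hydrogen-bond donors and acceptors, produces no difference that this read-out can separate from the usual scatter, which is the first single-place comparison; compound 2 differs from both of the others in more than one place, so its higher value cannot be tied to any one change. No available data bear on why the two groups read alike.

Still open, going by these compounds, is whether this insensitivity extends to groups of another kind on the carbonyl carbon, such as a plain phenyl ring, or to the same bicyclic groups carrying a carboxylic acid or a primary amine. Also open, on these data alone, is whether 1H-benzimidazol-6-yl reads the same when the piperidine-derived sulfonamide end of the molecule is replaced by a phenyl sulfone or by a morpholine.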